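The source may hold more compounds than are shown below. What is called first, only, known or untested is meant among the compounds shown, and "the series" means these compounds.

Measured so far:
Compound 1 `O=C1C=CC(OCC(F)(F)F)N1c1ccc(C(F)(F)F)cc1` — in a functional assay on MDA-MB-231 cells (Homo sapiens) for inhibition (on this read-out lower numbers stand for stronger inhibition and higher numbers for weaker inhibition), compound 1 gives 2300 nM.
Compound 2 `O=C1C=CC(OCC(F)(F)F)N1c1ccccc1` — in this assay compound 2 gives 15300 nM.

For the measured compounds named here, of these two numbers compound 2 holds the higher one; its nearest neighbour is compound 1, and the only measured step, a 6.7-fold higher number from compound 1 to compound 2 (0.82 log units; beyond the scatter), separates them. Compound 3 `O=C1C=CC(OCC(F)(F)F)N1c1ccc([N+](=O)[O-])cc1` has not yet been measured. Compound 3 differs from compound 2 by nitro in place of hydrogen on an aromatic carbon, at the place described as para to a large group. The step that bears on this change is a 6.7-fold higher number from compound 1 to compound 2 (0.82 log units; beyond the scatter), which shows that removing a group from that position of compound 1 raised the number by a modest but clear margin. Putting a nitro group back onto compound 2 at the same position is therefore expected to move the number back down, by a step estimated as a 3.8-fold lower number from compound 2 to compound 3 (0.58 log units; beyond the scatter). On that basis compound 3 is expected to give about 4000 nM in this assay, within a range from 1500 nM to 12000 nM.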

Compound 3, half-maximal inhibitory concentration: 2830 nM
Compound 3: middle estimate off by 1.4-fold (0.15 log units), on the high side; the measured number falls inside the stated range.
By their numbers in this assay, from the lowest: compounds 1 and 3 (each within the scatter of the next); then compound 2.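

In this assay, nitro in place of hydrogen gives a 5.4-fold lower number from compound 2 to compound 3 (0.73 log units; beyond the scatter) and so shows that the lower number at the place para to a large group is not tied to trifluoromethyl alone. Nitro in place of trifluoromethyl gives a 1.2-fold higher number from compound 1 to compound 3 (0.09 log units; within the scatter) and so does not separate these two groups in this read-out, leaving compound 2, with hydrogen at this place, as the only one of the three set apart by a step beyond the scatter. The data at hand give no reason for this shared result.

As far as these compounds go, the three compounds cover only hydrogen, trifluoromethyl and nitro at this place, so it remains open whether an amine, a methoxy group or a carboxylic acid there would give a number close to those of compound 1 and compound 3 or one closer to that of compound 2. All three compounds also share the rest of the core, so they cannot tell whether the same step would hold with a longer chain in place of the trifluoroethoxy group.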